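Methoxy Addition Tested for Cytotoxicity at One Concentration

A few compounds are considered here, and "the series" means these few. Any claim that something is new, unique, unknown or untested is made for them only; others in the source may bear on it.

Compound 1 `COc1ccc(-c2cc(/C=C/C(=O)c3ccc(N)cc3)[nH]n2)cc1`: 100%
Compound 2 `COc1ccc(C(=O)/C=C/c2cc(-c3cc(OC)c(OC)c(OC)c3)n[nH]2)cc1OC`: 100%
Compound 3 `COc1ccc(-c2cc(/C=C/C(=O)c3ccc(N)cc3)[nH]n2)cc1OC`: 91%

Three compounds have been run in a functional assay on HOP-62 cells (Homo sapiens) for cytotoxicity, read by sulforhodamine B assay, with a stated time of 48 h, tested at 0.1 uM; on this read-out higher numbers stand for a weaker effect at the one concentration tested and lower numbers for a stronger effect. In this assay compound 1 gives 100%, compound 2 gives 100% and compound 3 gives 91%. Compound 3 arises from compound 1 by methoxy in place of hydrogen on an aromatic carbon, and the step of a number 9 percentage points lower from compound 1 to compound 3 (within the scatter). The difference between the cores of compound 1 and compound 2 is not broken down here; their two values sit level at the digits printed.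

Compound 4 `COc1cc(C(=O)/C=C/c2cc(-c3cc(OC)c(OC)c(OC)c3)n[nH]2)cc(OC)c1OC` has not yet been measured. It arises from compound 2 by methoxy in place of hydrogen on an aromatic carbon, the same kind of change as that from compound 1 to compound 3, though here the entering group also stands meta to a methoxy group. In this assay compound 4 is expected to give about 97%, plausibly between 85% and 100%. The expected step is a number 3 percentage points lower from compound 2 to compound 4 (within the scatter), small because a number 9 percentage points lower from compound 1 to compound 3 (within the scatter) stayed within the scatter, and all three measured values already lie near the top of the read-out.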

Compound 4, a percentage reported as activity, at one concentration (the size of the read-out at that concentration, not a potency): 94%
The estimate for compound 4 lay 3 percentage points above the measured number; measured number inside the range.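

In this assay methoxy in place of hydrogen on an aromatic carbon of the core of compound 2 gives a number 6 percentage points lower from compound 2 to compound 4 (within the scatter) and this can be set beside the same change on the core of compound 1: the same change on two cores in this assay, a number 9 percentage points lower (within the scatter) from compound 1 to compound 3 and a number 6 percentage points lower (within the scatter) from compound 2 to compound 4, 3 percentage points apart, within the scatter of two such steps

As far as these two cores go, the change carries over from one to the other, with neither step leaving the scatter and no difference between the two steps. This does not show that methoxy has a real effect on either core, nor that the agreement would hold on any further core, as each step rests on a single pair read at one concentration near the top of the read-out.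

The compounds shown leave open what fluorine, a carboxylic acid or a longer chain such as ethoxy would give in place of this methoxy. They also leave open how the same change would read at any other concentration.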